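Series notes: fluoro for phenyl on two cores

The source may report more compounds than this note shows. Statements on the series, on what has been measured and on what is new or still open speak of the compounds shown alone.

Measured so far:
- compound 1, `C=C1CC(Cn2cc(C)c(=O)[nH]c2=O)(c2ccc(-c3ccccc3)cc2)OC1=O`: 1580 nM
- compound 2, `C=C1CC(Cn2cc(C)c(=O)[nH]c2=O)(c2ccc(F)cc2)OC1=O`: 4570 nM
- compound 3, `C=C1CC(Cn2ccc(=O)[nH]c2=O)(c2ccc(-c3ccccc3)cc2)OC1=O`: 955 nM

All three were run in a functional assay on TK-10 cells (Homo sapiens) for inhibition; on this read-out higher numbers stand for weaker inhibition of growth and lower numbers for stronger inhibition of growth. Compound 1 and compound 2 differ in one place, (fluoro in place of phenyl on an aromatic carbon), and the step of a 2.9-fold higher number from compound 1 to compound 2 (0.46 log units; beyond the scatter). Compound 1 and compound 3 differ in their cores, (hydrogen in place of methyl on an aromatic carbon), and the step of a 1.7-fold lower number from compound 1 to compound 3 (0.22 log units; within the scatter), so the two cores cannot be told apart on this read-out.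

Compound 4, `C=C1CC(Cn2ccc(=O)[nH]c2=O)(c2ccc(F)cc2)OC1=O`, has not been measured. It stands to compound 3 as compound 2 stands to compound 1: the change is fluoro in place of phenyl on an aromatic carbon. The two descriptions of the place agree word for word, so it is the same change, made here on the core of compound 3 instead of the core of compound 1.

Going by the values given here, only one example of this change has been measured. The expectation for compound 4 therefore rests on the step from compound 1 to compound 2, with the step between the cores treated as negligible since it lies within the scatter. Compound 4 is expected to show a step of about a 2.9-fold higher number from compound 3 to compound 4 (0.47 log units; beyond the scatter) in this assay, beside the measured one, because the pair compound 1 to compound 2 gave a 2.9-fold higher number from compound 1 to compound 2 (0.46 log units; beyond the scatter). With a single precedent the range is kept wide.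

Compound 4 is estimated at 2800 nM, with a likely span from 1200 nM to 6500 nM.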

Compound 4, concentration for 50% growth inhibition: 14500 nM
The estimate for compound 4 lay 5.2-fold (0.71 log units) below the measured number; the whole stated range lies below it.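

In this assay, fluoro in place of phenyl on an aromatic carbon raised the number on both cores, but the size of the step did not carry over from one core to the other, with a 15-fold higher number from compound 3 to compound 4 (1.18 log units; beyond the scatter) set against the earlier step: the same change on two cores in this assay, a 2.9-fold higher number (0.46 log units; beyond the scatter) from compound 1 to compound 2 and a 15-fold higher number (1.18 log units; beyond the scatter) from compound 3 to compound 4, 5.2-fold (0.72 log units) apart, beyond the scatter of two such steps

The same square read the other way shows hydrogen in place of methyl on an aromatic carbon making no step beyond the scatter with phenyl on the ring, but giving a 3.2-fold higher number from compound 2 to compound 4 (0.50 log units; beyond the scatter) with fluoro there: the same change on two cores in this assay, a 1.7-fold lower number (0.22 log units; within the scatter) from compound 1 to compound 3 and a 3.2-fold higher number (0.50 log units; beyond the scatter) from compound 2 to compound 4, 5.2-fold (0.72 log units) apart, beyond the scatter of two such steps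

So the direction of the change held across the two cores while its size did not, which means a step measured on one core is a poor guide to its size on the other; these four compounds form a single square, however, and they give neither a cause for the gap nor any sign that it is general.

Open, from the compounds shown here alone, is whether an amine, a methoxy group or a carboxylic acid on the same aromatic carbon would also show a step that depends on the core. Also open, going by these compounds, is whether the gap seen here would persist with such groups, or is peculiar to the pairing of fluoro with the core of compound 3.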